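A few compounds are considered here, and "the series" means these few. Any claim that something is new, unique, unknown or untested is made for them only; others in the source may bear on it.

Compound 1 `CC(C)Sc1nnc(-c2c(CN3CCCCC3C)c3ccccc3n2C)n1-c1ccccc1` gives 5.95 in a physicochemical assay for lipophilicity (a higher number here means a more lipophilic compound, a lower number a more polar compound), the second highest of the three values known: compound 3 `COc1ccc(CNCc2c(-c3nnc(SC(C)C)n3-c3ccccc3)n(C)c3ccccc23)cc1` gives 6.27, while compound 2 `CC(C)Sc1nnc(-c2c(CNc3cnccn3)c3ccccc3n2C)n1-c1ccccc1` gives 4.22. The steps run a number 0.32 log units higher from compound 1 to compound 3 (beyond the scatter) and a number 1.73 log units lower from compound 1 to compound 2 (beyond the scatter), and between the other pair a number 2.05 log units higher from compound 2 to compound 3 (beyond the scatter). Compound 4 `COc1cccc(CNCc2c(-c3nnc(SC(C)C)n3-c3ccccc3)n(C)c3ccccc23)c1` awaits measurement; it differs from compound 1 as follows: (3-methoxybenzyl)amino in place of 2-methylpiperidin-1-yl on a saturated chain carbon bound to an aromatic carbon. Among the measured compounds shown here, the step that bears on this is the one from compound 1 to compound 3, where the entering group was (4-methoxybenzyl)amino rather than (3-methoxybenzyl)amino and gave a modest rise. A step of similar size and direction is therefore expected, a number 0.30 log units higher from compound 1 to compound 4 (within the scatter), in this assay. Compound 4 is accordingly estimated at 6.25, with a range from 5.85 to 6.65.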

Compound 4, partition coefficient: 6.27
Beside the measured number, compound 4's estimate is 0.02 log units below it; the measured number falls inside the stated range.
By their numbers in this assay, from the lowest: compound 2; then compound 1; then compounds 3 and 4 (each within the scatter of the next).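

In this assay, 3-methoxyphenyl in place of 4-methoxyphenyl on a saturated chain carbon bound to an amine nitrogen gives no change at the digits printed from compound 3 to compound 4 (within the scatter). The (3-methoxybenzyl)amino group matches the (4-methoxybenzyl)amino group in its steps, with a number 0.32 log units higher from compound 1 to compound 4 (beyond the scatter) and, for 3-methoxybenzyl in place of pyrazin-2-yl on the amine nitrogen, a number 2.05 log units higher from compound 2 to compound 4 (beyond the scatter). Nothing at hand gives a reason for these steps.

Going by these compounds, what remains open is the number that an unsubstituted benzyl, a 2-methoxybenzyl or a 3-carboxybenzyl on that amine nitrogen would give.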